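Series notes: heteroaryl exchange, compound 3 to compound 4

A few compounds are considered here, and "the series" means these few. Any claim that something is new, unique, unknown or untested is made for them only; others in the source may bear on it.

Measured in an assay on isolated protein for inhibition of DNA topoisomerase 1 (Homo sapiens), with a stated time of 30 min, tested at 20 uM (on this read-out higher numbers stand for a stronger effect at the one concentration tested and lower numbers for a weaker effect), so far:
compound 1 `Oc1cccc(-c2cc(-c3ccccc3)cc(-c3ccsc3)n2)c1` — compound 1 gives 6.8%
compound 2 `Oc1cccc(-c2cc(-c3ccccc3)nc(-c3ccccc3)c2)c1` — compound 2 gives 0%
compound 3 `Oc1cccc(-c2cc(-c3ccccc3)nc(-c3ccsc3)c2)c1` — compound 3 gives 3.2%

Among the measured compounds shown here, all three numbers sit within the scatter of one another, so no compound can be set apart from the others. Compound 3 sits among them with compound 2 as its nearest neighbour and compound 1 as its furthest, both within the scatter.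

The next compound is compound 4 `Oc1cccc(-c2cc(-c3ccccc3)nc(-c3cccnc3)c2)c1`. It differs from compound 3 as follows: pyridin-3-yl in place of thiophen-3-yl on an aromatic carbon.

For the measured compounds named here, the one step in this assay that bears on this kind of exchange is a number 3.2 percentage points higher from compound 2 to compound 3 (within the scatter), which swapped one aryl group for another at the same position and left the number essentially where it was. Nothing in the series shows a move beyond the scatter for any change at this position, and the exchange of thiophen-3-yl for pyridin-3-yl is of the same kind. The expectation is therefore no step beyond the scatter: a number 0.2 percentage points lower from compound 3 to compound 4 (within the scatter) is the expected step. For compound 4 the estimated value in this assay is 3%, with an expected range from 0% to 12%.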

Compound 4, a percentage reported as inhibition, at one concentration (the size of the read-out at that concentration, not a potency): 1.5%
Estimate against measurement, compound 4: 1.5 percentage points above; the measured number falls inside the stated range.
By their numbers in this assay, from the lowest: compounds 2, 4, 3 and 1 (each within the scatter of the next).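

Position next to the ring nitrogen: in this assay, a number 1.7 percentage points lower from compound 3 to compound 4 (within the scatter) and a number 1.5 percentage points higher from compound 2 to compound 4 (within the scatter) set pyridin-3-yl against both earlier groups, and neither step leaves the scatter. Phenyl, thiophen-3-yl and pyridin-3-yl, five-membered and six-membered aromatic rings alike, are therefore not told apart at this position at the one concentration tested, which widens the earlier single exchange to three groups. No measurement at hand explains why these numbers stay together.

Still open, on these data alone, is whether a group of another kind at this position, such as an amine, a carboxylic acid or a longer alkyl chain, would move the number beyond the scatter. Also open, as far as these compounds go, is how the series responds to a change elsewhere, such as a methoxy group in place of the hydroxyl of the 3-hydroxyphenyl group.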